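Moving the bromine around the ring: compound 3 expected

A few compounds are considered here, and "the series" means these few. Any claim that something is new, unique, unknown or untested is made for them only; others in the source may bear on it.

Measured so far:
Compound 1 `O=C(NCC1CCCCC1)N1C(=O)c2ccccc2S1(=O)=O` gives 0.963 h in a physicochemical assay for pharmacokinetics; on this read-out lower numbers stand for a shorter-lived compound and higher numbers for a longer-lived compound.
Compound 2 `O=C(NCc1ccccc1Br)N1C(=O)c2ccccc2S1(=O)=O` gives 0.253 h in this assay.

Among the measured compounds shown here, compound 2 holds the lowest of the two numbers; the only other value is that of compound 1, reached by the step of a 3.8-fold lower number from compound 1 to compound 2 (0.58 log units; beyond the scatter). Compound 3 `O=C(NCc1ccc(Br)cc1)N1C(=O)c2ccccc2S1(=O)=O` differs from compound 2 by 4-bromophenyl in place of 2-bromophenyl on a saturated chain carbon bound to an amide-type nitrogen. For the measured compounds named here, no measured step swaps one bromophenyl for another, so the single known step does not bear directly on it; the same atoms are merely joined differently. The expected step from compound 2 to compound 3 in this assay is therefore a 1.2-fold higher number from compound 2 to compound 3 (0.07 log units; within the scatter), within the scatter. For compound 3 the estimate in this assay is 0.3 h, ranging from 0.12 h to 0.75 h.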

Compound 3, half-life: 0.187 h
For compound 3 the middle estimate is 1.6-fold (0.21 log units) above the measured one; the range from low to high includes it.
By their numbers in this assay, from the lowest: compounds 3 and 2 (each within the scatter of the next); then compound 1.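

In this assay, the bromine's place on the ring makes little difference here, as 4-bromophenyl in place of 2-bromophenyl gives a 1.4-fold lower number from compound 2 to compound 3 (0.13 log units; within the scatter). The two bromophenyl groups therefore cannot be told apart at this place on the chain, while the drop from cyclohexyl holds for the second bromophenyl group as well, with a 5.1-fold lower number from compound 1 to compound 3 (0.71 log units; beyond the scatter). Nothing available explains either step. Still open, as far as these compounds go, is whether a phenyl ring without bromine, or one carrying an amine or a carboxylic acid, would give a number closer to that of compound 1 . A longer chain between the amide-type nitrogen and the ring is equally untested by the compounds shown.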